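The compounds below may be only part of what the source reports. "The series", "measured", "known", "first", "only" and "open" are said of these compounds alone.

Compound 1, `Cc1ccc(/C=C2\CCC/C(=C\c3ccc([N+](=O)[O-])cc3)C2=O)cc1`, gives 8160 nM in a functional assay on L1210 cells (Mus musculus) for cytotoxicity, with a stated time of 48 h; a lower number here means a stronger inhibitor, a higher number a weaker inhibitor.
Compound 2, `O=C1/C(=C/c2ccc(Cl)cc2)CCC/C1=C\c1ccc([N+](=O)[O-])cc1`, gives 9410 nM in this assay.
Compound 3, `CN(C)c1ccc(/C=C2\CCC/C(=C\c3ccc([N+](=O)[O-])cc3)C2=O)cc1`, gives only > 500000 nM in this assay, which is a limit of the assay and not a number.

All three share one core and differ only in the group on the second aromatic ring. Compound 3 stands apart from the other two, since in this assay its result is a limit (the limit of > 500000 nM in this assay, at which 1 of the 3 values shown sits), so its true value is not known. Compound 4, `O=C1/C(=C/c2ccccc2)CCC/C1=C\c1ccc([N+](=O)[O-])cc1`, has not yet been measured. It differs from compound 3 by hydrogen in place of dimethylamino on an aromatic carbon. Going by the values given here, two measured steps bear on this change: an at least 61-fold higher number from compound 1 to compound 3 (1.78 log units; beyond the scatter) and an at least 53-fold higher number from compound 2 to compound 3 (1.72 log units; beyond the scatter), both large and beyond the scatter, showing that placing dimethylamino at this position brings the number up to the limit. By contrast, a 1.2-fold higher number from compound 1 to compound 2 (0.06 log units; within the scatter) is within the scatter, so exchanging one small group for another at this position changes little. Removing dimethylamino to leave hydrogen is the reverse of the large steps, so a large drop in this assay is expected, toward the values of compound 1 and compound 2. Compound 4 is therefore estimated at 9000 nM, with a range from 3000 nM to 30000 nM. This amounts to an expected step of an at least 55-fold lower number from compound 3 to compound 4 (1.74 log units; beyond the scatter).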

Compound 4, half-maximal inhibitory concentration: 9800 nM
For compound 4 the middle estimate is 1.1-fold (0.04 log units) below the measured one; the range from low to high includes it.
By their numbers in this assay, from the lowest: compounds 1, 2 and 4 (each within the scatter of the next). At a limit, above all of these: compound 3.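

Compound 4 carries only hydrogen on this aromatic carbon, and in this assay it cannot be told apart from the methyl and chloro compounds, as a 1.2-fold higher number from compound 1 to compound 4 (0.08 log units; within the scatter) and a 1.0-fold higher number from compound 2 to compound 4 (0.02 log units; within the scatter) both lie within the scatter. Against this plain hydrogen baseline, removing dimethylamino gives an at least 51-fold lower number from compound 3 to compound 4 (1.70 log units; beyond the scatter) and so ties the loss of activity to dimethylamino itself, not to the mere presence of a group on this carbon, which methyl and chloro had already suggested but could not show without a compound bearing hydrogen. Compound 3 remains a limit of the assay and not a number, so the true size of this step is unknown: the limit of > 500000 nM in this assay, at which 1 of the 4 values shown sits.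

The compounds shown leave open whether this loss is specific to dimethylamino or extends to other groups, such as a primary amine, a methoxy group or a carboxylic acid on the same carbon. They also leave open whether a similar change would matter on the other aromatic ring, where all four compounds keep the same nitro group.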